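Removing the cyclohexylamino group from compound 2

A few compounds are considered here, and "the series" means these few. Any claim that something is new, unique, unknown or untested is made for them only; others in the source may bear on it.

Compound 1 `N=C(Nc1ccccc1)c1cc2c(-c3ccccc3)n[nH]c2c(NC2CCCCC2)n1`: 1730 nM
Compound 2 `CN1CCN(c2ccc(NC(=N)c3cc4c(-c5ccccc5)n[nH]c4c(NC4CCCCC4)n3)cc2)CC1`: 4630 nM
Compound 3 `COc1ccc(Cn2nc(-c3ccccc3)c3cc(C(=N)Nc4ccc(N5CCN(C)CC5)cc4)nc(NC4CCCCC4)c32)cc1`: 3540 nM

In a functional assay on PC-3 cells (Homo sapiens) for cytotoxicity, read by MTT assay, with a stated time of 72 h (on this read-out higher numbers stand for weaker inhibition and lower numbers for stronger inhibition), compound 2 gives the highest of the three numbers. Its nearest neighbour is compound 3, with a 1.3-fold lower number from compound 2 to compound 3 (0.12 log units; within the scatter), a step within the scatter. Compound 1 lies further away, with a 2.7-fold higher number from compound 1 to compound 2 (0.43 log units; beyond the scatter), a modest step beyond the scatter.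

Compound 4 `CN1CCN(c2ccc(NC(=N)c3cc4c(-c5ccccc5)n[nH]c4cn3)cc2)CC1` differs from compound 2 in one place: hydrogen in place of cyclohexylamino on an aromatic carbon. Neither measured step touches this part of the shared core. The step from compound 1 to compound 2 changes the aryl substituent on the amidine side, and the step from compound 2 to compound 3 changes the substituent on the aromatic nitrogen; the cyclohexylamino group is present in all three measured compounds, so nothing measured shows what its loss does. With a group of seven heavy atoms leaving and only a hydrogen entering, the expectation is a higher number in this assay, and the estimate for compound 4 is 12000 nM, in the range 3000 nM to 50000 nM, a step of a 2.6-fold higher number from compound 2 to compound 4 (0.41 log units; beyond the scatter), though the uncertainty is large.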

Compound 4, half-maximal inhibitory concentration: 17100 nM
Estimate against measurement, compound 4: 1.4-fold (0.15 log units) below; measured number inside the range.
By their numbers in this assay, from the lowest: compound 1; then compounds 3 and 2 (each within the scatter of the next); then compound 4.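

Replacing cyclohexylamino with hydrogen on the aromatic carbon next to the ring nitrogen gives, in this assay, a 3.7-fold higher number from compound 2 to compound 4 (0.57 log units; beyond the scatter). This position, unchanged across compounds 1, 2 and 3, is therefore not indifferent in this read-out: with the methylpiperazinyl aryl group held constant, the number depends on whether cyclohexylamino is present. Nothing on hand explains why the number rises when the group leaves.

The pair cannot separate the part played by the amine nitrogen from that of the cyclohexane ring, and a methylamino, a cyclopentylamino or a cyclohexyl group joined directly through carbon would be needed to do so. From the compounds shown here alone, whether the loss of cyclohexylamino costs the same with the plain phenyl amidine of compound 1 or the 4-methoxybenzyl group of compound 3 also stays open.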